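A Fluorophenylamino Group Replaces Dipropylamino

This account rests on a few compounds, and the source may have more. Where it says the series, first, only, none or still open, it means among the compounds named here.

In a functional assay on HeLa cells (Homo sapiens) for inhibition, read by sulforhodamine B assay (a lower number here means a stronger inhibitor, a higher number a weaker inhibitor), compound 2 `CCCN(CCC)C1=CC(=O)c2c(nc3n2[C@H]2OC[C@@H](O)[C@H]2OC3)C1=O` gives only a limit, > 16000 nM. Among the compounds with values here, the one other value is also a limit: compound 1 `COc1ccc(NC2=CC(=O)c3c(nc4n3[C@H]3OC[C@@H](O)[C@H]3OC4)C2=O)cc1` gives > 8000 nM. Neither compound therefore has a readable potency, and compound 2 cannot be ranked against compound 1.

Compound 3 `O=C1C(Nc2cccc(F)c2)=CC(=O)c2c1nc1n2[C@H]2OC[C@@H](O)[C@H]2OC1` has (3-fluorophenyl)amino in place of dipropylamino on a double-bonded ring carbon of the shared core ((3-fluorophenyl)amino in place of dipropylamino on a double-bonded ring carbon). Compound 1 carries (4-methoxyphenyl)amino on that carbon, so compound 3 regains an aromatic ring on the amino group. Within the data shown here, the only measured step, a step that the two limits leave unreadable from compound 1 to compound 2, involves the same carbon, but it offers no size to carry over.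

Compound 3 is therefore expected to remain a weak inhibitor in this assay, quite possibly reported only as a limit. That expectation rests on compound 1, whose limit is > 8000 nM. The expected change is an at least 1.3-fold lower number from compound 2 to compound 3 (0.12 log units; that floor lies within the scatter), a small shift towards stronger inhibition, if any. For compound 3 the estimated value is 12000 nM, with an expected range of 4000 nM to 32000 nM.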

Compound 3, half-maximal inhibitory concentration: > 8000 nM
Compound 3: no number, only a limit (the forecaster's own chance of this, stated with the estimate: 65%); the middle value lies beyond the limit too.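

In this assay compound 3 gives > 8000 nM, a limit and not a number. The steps to compound 3 from compound 1 and from compound 2 therefore cannot be read. The compounds shown leave open whether any amino group on this double-bonded ring carbon gives a readable potency, and how far compound 1, compound 2 and compound 3 actually differ.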